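Swapping Nitro for Cyano: An Outlook on Growth Inhibition

The source may hold more compounds than are shown below. What is called first, only, known or untested is meant among the compounds shown, and "the series" means these compounds.

Measured so far:
compound 1, `CC(=O)c1ccc(Nc2ccnc(SCC(=O)c3ccc(Br)cc3)n2)cc1`, giving 29%
compound 2, `CCOC(=O)c1ccc(Nc2ccnc(SCC(=O)c3ccc([N+](=O)[O-])cc3)n2)cc1`, giving 37%

Of the compounds shown here, two sharing one core have been tested in a functional assay on NCI-H522 cells (Homo sapiens) for inhibition, read by sulforhodamine B assay, with a stated time of 48 h, tested at 10 uM; on this read-out higher numbers stand for more inhibition of growth at the one concentration tested and lower numbers for less inhibition of growth. In this assay compound 1 gives 29%, and compound 2 gives 37%. Compound 2 holds the higher of the two numbers, but its nearest neighbour, compound 1, sits within the usual scatter, so the two values show no real separation. Among the measured compounds shown here, the two compounds also differ in more than one place, so no single step between them can be read.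

Compound 3, `CCOC(=O)c1ccc(Nc2ccnc(SCC(=O)c3ccc(C#N)cc3)n2)cc1`, has not yet been measured in this assay. It differs from compound 2 in one place only: cyano in place of nitro on an aromatic carbon. For the measured compounds named here, no measured pair in this set shows what such a change does here, so there is no step to lean on. With nothing pointing either way, the step from compound 2 to compound 3 is expected to stay within the scatter, in no set direction, estimated as a number 4 percentage points lower from compound 2 to compound 3 (within the scatter). Compound 3 is therefore expected to give about 33%, with a likely range from 15% to 52%.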

Compound 3, percent growth inhibition at one concentration: 73%
The estimate for compound 3 lay 40 percentage points below the measured number; the whole stated range lies below it.
By their numbers in this assay, from the lowest: compounds 1 and 2 (each within the scatter of the next); then compound 3.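

Among the compounds shown here, with the rest of compound 2 left unchanged, putting cyano in place of nitro on the aromatic carbon para to a large group gives a number 36 percentage points higher from compound 2 to compound 3 (beyond the scatter) in this assay, the first step in this set that can be read at a single place. The earlier compounds shown here could not show this, as they differ in more than one place and their values lie within the scatter of each other; this pair shows that the read-out at this position is sensitive to the group it carries, and that 4-cyanophenyl and 4-nitrophenyl are far from interchangeable here. Nothing at hand bears on what lies behind the step, so the result stands as an observation about these two groups alone.

As far as these compounds go, it remains open whether cyano is unusual at this position or whether other groups there, such as an amine, a carboxylic acid or a methoxy group, would give a similar number. From the compounds shown here alone, it is also open whether the same change would give a step of similar size with the ethyl ester at the other end of the molecule replaced by another group, such as the acetyl group of compound 1.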